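The compounds below may be only part of what the source reports. "The series", "measured", "known", "first", "only" and "open" are said of these compounds alone.

Of the compounds shown here, three have been measured in a functional assay on MDA-MB-231 cells (Homo sapiens) for antiproliferative activity, read by sulforhodamine B assay, with a stated time of 72 h; a higher number here means a weaker inhibitor, a lower number a stronger inhibitor. Compound 1 (`Fc1ccc(/C=C/c2cc3ccccc3nc2Cl)cc1`) reaches only a limit in this assay, > 50000 nM. Compound 2 (`COc1ccc2nc(Cl)c(/C=C/c3ccc(C(F)(F)F)cc3)cc2c1`) gives 48800 nM, while compound 3 (`COc1ccc2nc(Cl)c(/C=C\c3ccc(F)cc3)cc2c1`) gives 11400 nM, the lower of the two numbers and clearly apart from it. Compound 4 (`COc1ccc2nc(Cl)c(/C=C/c3ccc(F)cc3)cc2c1`) differs from compound 3 by the two compounds have the same atoms and bonds and differ only in configuration as drawn: 1 of 1 stereo elements differ; a double bond is drawn Z in compound 3 and E in compound 4: a double bond is drawn Z in compound 3 and E in compound 4. Compound 2, also drawn E though with trifluoromethyl in place of fluorine, stands at 48800 nM, so a weaker result is expected for the E form. The expected change is a 2.6-fold higher number from compound 3 to compound 4 (0.42 log units; beyond the scatter), toward a higher number and beyond the scatter. For compound 4 the estimated value is 30000 nM, within a range of 12000 nM to 60000 nM.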

Compound 4, half-maximal inhibitory concentration: 11000 nM
For compound 4 the middle estimate is 2.7-fold (0.44 log units) above the measured one; measured number below the stated range.
By their numbers in this assay, from the lowest: compounds 4 and 3 (each within the scatter of the next); then compound 2. At a limit, above all of these: compound 1.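

In this assay, reversing the double bond from Z to E leaves the number within the scatter, a 1.0-fold lower number from compound 3 to compound 4 (0.02 log units; within the scatter). With both compounds drawn E, fluoro in place of trifluoromethyl on an aromatic carbon gives a 4.4-fold lower number from compound 2 to compound 4 (0.65 log units; beyond the scatter). Methoxy in place of hydrogen on an aromatic carbon gives an at least 4.5-fold lower number from compound 1 to compound 4 (0.65 log units; beyond the scatter), a step that can only be read as a bound, as compound 1 stands at a limit: the limit of > 50000 nM in this assay, at which 1 of the 4 values shown sits.

On these data alone, it remains open whether the Z and E forms also stay this close with trifluoromethyl on the aromatic ring. An amine or a carboxylic acid in place of the fluoro also remains untested among the compounds shown.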